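From a Chloro to a Nitro Group: Expected Tolerance

This account rests on a few compounds, and the source may have more. Where it says the series, first, only, none or still open, it means among the compounds named here.

Three compounds have so far been measured in an ADME assay on HepG2 cells (Homo sapiens) for cytotoxicity, read by MTT assay, with a stated time of 72 h; a higher number here means that more compound is tolerated, a lower number that less compound is tolerated:

Compound 1 `Clc1ccc(/C=N/c2sc3c(c2-c2nc4ccccc4s2)CCC3)cc1` gives 431 ug/mL
Compound 2 `Clc1ccccc1/C=N/c1sc2c(c1-c1nc3ccccc3s1)CCC2` gives 180 ug/mL
Compound 3 `Clc1ccc(/C=N/c2sc3c(c2-c2nc4ccccc4s2)CCCC3)cc1` gives 397 ug/mL

Compound 3 stands second highest of the three numbers. Its value sits close to that of compound 1, within the usual scatter, so the two cannot be ranked against each other. Compound 2 lies lower than compound 3, beyond the scatter.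

Compound 4 `O=[N+]([O-])c1ccc(/C=N/c2sc3c(c2-c2nc4ccccc4s2)CCCC3)cc1` differs from compound 3 in one place: nitro in place of chloro on an aromatic carbon.

Among the compounds with values here, only one step between measured compounds is known, a 2.4-fold lower number from compound 1 to compound 2 (0.38 log units; beyond the scatter), and it concerns where the chloro group sits on the ring rather than what group occupies that spot. Within the data shown here, no measured step exchanges one group for another at the same position, so nothing directly bears on the change from chloro to nitro. With no guidance pointing in either direction, the expectation in this assay is a step of about zero, no larger than the scatter.

The estimate for compound 4 is therefore 400 ug/mL, with a range from 200 ug/mL to 800 ug/mL, which means an expected step of a 1.0-fold higher number from compound 3 to compound 4 (0.00 log units; within the scatter).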

Compound 4, half-maximal cytotoxic concentration: 454 ug/mL
For compound 4 the middle estimate is 1.1-fold (0.05 log units) below the measured one; the range from low to high includes it.
By their numbers in this assay, from the lowest: compound 2; then compounds 3, 1 and 4 (each within the scatter of the next).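

In this assay the exchange of chloro for nitro on this aromatic carbon gives a step within the scatter (a 1.1-fold higher number from compound 3 to compound 4 (0.06 log units; within the scatter)), so 4-chlorophenyl and 4-nitrophenyl cannot be told apart here, even though nitro brings more heavy atoms and two hydrogen-bond acceptors that chloro lacks. Within the data shown here, this is the first measured exchange of one group for another at this position, whereas the earlier step (a 2.4-fold lower number from compound 1 to compound 2 (0.38 log units; beyond the scatter)) showed only what happens when 2-chlorophenyl stands in place of 4-chlorophenyl. Nothing available explains why the two groups read alike, so the result stands as an observation without a known cause.

On these data alone, two groups that read alike say little about the others, so it remains open whether an amine, a carboxylic acid or a methoxy group on this carbon would give a number beyond the scatter from that of compound 3. As far as these compounds go, it is also open whether 2-nitrophenyl would differ from 4-nitrophenyl in the way that 2-chlorophenyl differs from 4-chlorophenyl.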